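The source may report more compounds than this note shows. Statements on the series, on what has been measured and on what is new or still open speak of the compounds shown alone.

Measured so far, in a functional assay on CHO cells for agonist activity at metabotropic glutamate receptor 2 (Homo sapiens), read by GTPgammaS binding; a lower number here means that less compound is needed, a higher number that more compound is needed for the effect:

compound 1, `CCCn1ccc2cc(-c3cncnc3)cc(Cl)c2c1=O`, gives 3980 nM
compound 2, `CCCn1ccc2cc(NCc3cccnc3)cc(Cl)c2c1=O`, gives 3160 nM
compound 3, `CCCn1ccc2cc(-c3ccc(Oc4ccccc4)cc3)cc(Cl)c2c1=O`, gives 2000 nM

All three compounds share the same core and differ only in the group attached to it. Compound 3 has the lowest number of the three in this assay, but its gaps to compound 2 and to compound 1 both lie within the usual scatter, so no real ordering among them can be claimed.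

Compound 4, `CCCn1ccc2cc(-c3ccc(OCc4ccc(Cl)nc4)cc3)cc(Cl)c2c1=O`, is the next step from compound 3. The change is (6-chloropyridin-3-yl)methyl in place of phenyl on an oxygen on an aromatic ring. Going by the values given here, no measured pair shows what such a change does here, so the expectation rests on compound 3 alone. A modest step towards a lower number is expected, a 2.5-fold lower number from compound 3 to compound 4 (0.40 log units; beyond the scatter), since the group grows but keeps its place. Compound 4 is therefore estimated at 800 nM, with a likely range from 250 nM to 2500 nM.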

Compound 4, half-maximal effective concentration: 398 nM
Beside the measured number, compound 4's estimate is 2.0-fold (0.30 log units) above it; the range from low to high includes it.
By their numbers in this assay, from the lowest: compound 4; then compounds 3, 2 and 1 (each within the scatter of the next).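

In this assay, going by these compounds alone, putting (6-chloropyridin-3-yl)methyl in place of phenyl on this oxygen gives a 5.0-fold lower number from compound 3 to compound 4 (0.70 log units; beyond the scatter) as the first step in this set beyond the scatter. The number therefore responds to what sits on this oxygen, and the larger group is accepted here. Nothing shown explains why the number falls.

From the compounds shown here alone, the change brings in a ring nitrogen, a chlorine and an extra carbon at once, so which of these matters stays open. Going by these compounds, whether a plain benzyl group, or an amine in place of the chlorine, would give a similar number is also open.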